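Trimming an Isopropyl to Ethyl on an Inactive Core

The source may report more compounds than this note shows. Statements on the series, on what has been measured and on what is new or still open speak of the compounds shown alone.

Compound 1 `CCc1nc(C)c2cnnc(SC)n12`: > 48000 nM
Compound 2 `CCCc1nc(C)c2c(-c3ccccc3)nnc(SC)n12`: > 48000 nM
Compound 3 `CSc1nnc(-c2ccccc2)c2c(C)nc(C(C)C)n12`: > 48000 nM

Each of these three values is a limit of the assay, not a measured number. In a functional assay for inhibition, with Homo sapiens as the target (a higher number here means a weaker inhibitor, a lower number a stronger inhibitor), compound 1 reaches only the limit > 48000 nM. Compound 2 likewise reaches only the limit > 48000 nM. Compound 3 stands at the limit > 48000 nM as well. This is summed up by the limit of > 48000 nM in this assay, at which 3 of the 3 values shown sit, so compound 3 has no true value to compare with, and the two further values around it are limits too.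

Compound 4 `CCc1nc(C)c2c(-c3ccccc3)nnc(SC)n12` differs from compound 3 as follows: hydrogen in place of methyl on a saturated chain carbon bound to an aromatic carbon and a saturated chain carbon. For the measured compounds named here, the only measured step between compounds differing in one place is a step that the two limits leave unreadable from compound 2 to compound 3, and its size cannot be read because both ends are limits. Compound 1 already carries the ethyl that enters in compound 4, and compound 2 and compound 3 already carry the phenyl that compound 4 keeps; all three sit at the limit. Compound 4 is therefore expected to stay at the limit, and the step that the limit leaves unreadable from compound 3 to compound 4 is expected to show no change beyond the scatter. The estimate for compound 4 is 70000 nM, within a range from 25000 nM to 300000 nM.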

Compound 4, half-maximal inhibitory concentration: > 48000 nM
Compound 4 ended at the assay's limit (the forecaster's own chance of this, stated with the estimate: 85%); the middle value is on the limit's open side.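

Compound 4 also gives only a limit, so its steps from compound 1, compound 2 and compound 3 cannot be read, because both ends of each step are limits: the limit of > 48000 nM in this assay, at which 4 of the 4 values shown sit. In this assay the compounds shown leave open which change to the shared core, if any, would give a true value rather than a limit.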